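The source may hold more compounds than are shown below. What is called first, only, known or untested is meant among the compounds shown, and "the series" means these compounds.

Compound 1 `CCOC(=O)CCCCCOc1cccc(CN(C(=O)c2ccc(-c3cccc(OCc4ccccc4)c3)cc2)C(C)C)c1` and compound 2 `CCOC(=O)CCCCCOc1cccc(CN(C(=O)c2ccc(-c3ccc4cc[nH]c4c3)cc2)C(C)C)c1` share a core and differ only in the aryl group at its far end. In an ADME assay on HepG2 cells (Homo sapiens) for cytotoxicity, read by CellTiter-Glo and resazurin assay, with a stated time of 72 h (on this read-out higher numbers stand for an effect only at larger amounts of compound and lower numbers for an effect already at smaller amounts), compound 1 gives only a limit, > 26000 nM, and no number. In this assay compound 2 likewise reaches only a limit, > 26000 nM. Compound 2 therefore stands where every value shown stands: the limit of > 26000 nM in this assay, at which 2 of the 2 values shown sit, so no cytotoxicity could be resolved for either compound within the tested range.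

Compound 3 `CCOC(=O)CCCCCOc1cccc(CN(C(=O)c2ccc(-c3cccc(OC(F)(F)F)c3)cc2)C(C)C)c1` is the next member. It differs from compound 2 by 3-(trifluoromethoxy)phenyl in place of 1H-indol-6-yl on an aromatic carbon. Within the data shown here, no measured pair shows what such an exchange does in this assay, so no size or direction can be drawn from the data; both compounds shown sit at the same limit, which gives no room for a measurable step in either direction.

For compound 3 the expectation is that the step from compound 2 a number no higher from compound 2 to compound 3 (the limit leaves the size open) stays within the scatter, and the estimate is 26000 nM, with a range from 12000 nM to 60000 nM, most likely again reported only as a limit.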

Compound 3, half-maximal effective concentration: > 26000 nM
Compound 3: no number, only a limit; the forecaster's own chance of this, stated with the estimate: 75%; the middle value sits exactly at the limit.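

In this assay, among these compounds, compound 3 gives only a limit, > 26000 nM, so no step to it from compound 1 or compound 2 can be read. The compounds shown leave open at what concentration any of them would harm these cells, and whether the exchanged end group alters that concentration: the limit of > 26000 nM in this assay, at which 3 of the 3 values shown sit.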